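This account rests on a few compounds, and the source may have more. Where it says the series, first, only, none or still open, it means among the compounds named here.

In a functional assay on MDA-MB-435 cells (Homo sapiens) for cytotoxicity, read by MTT assay, with a stated time of 72 h (on this read-out higher numbers stand for weaker inhibition and lower numbers for stronger inhibition), compound 2 `C[C@H](Nc1c(C(=O)NCc2ccc(F)cc2)nc(Br)c2cccnc12)c1ccccc1` gives > 20000 nM as a limit, not a number. Compound 1 `CS(=O)(=O)Oc1c(C(=O)NCc2ccc(F)cc2)nc(Br)c2cccnc12` gives > 20000 nM as a limit too. For the measured compounds named here, the only measured step that the two limits leave unreadable from compound 1 to compound 2 has no size to carry forward, and the limit of > 20000 nM in this assay, at which 2 of the 2 values shown sit, applies to both compounds. Compound 3 `COC(=O)CNc1c(C(=O)NCc2ccc(F)cc2)nc(Br)c2cccnc12` carries (methoxycarbonyl)methyl in place of 1-phenylethyl on a nitrogen on an aromatic ring. Going by the values given here, no measured step supports a shift in either direction, so none beyond the scatter is expected, and another limit is likely. The expected step (a step that the limit leaves unreadable from compound 2 to compound 3) has no measured size behind it. Compound 3 is expected near 25000 nM (estimated range 10000 nM to 60000 nM).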

Compound 3, half-maximal inhibitory concentration: 10000 nM
Compound 3: the middle estimate sits 2.5-fold (0.40 log units) above what was measured; measured number inside the range.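

In this assay, for the compounds shown here, compound 3 gives 10000 nM, the first value at this position that is a number and not a limit. (Methoxycarbonyl)methyl on the nitrogen gives an at least 2.0-fold lower number from compound 2 to compound 3 (0.30 log units; that floor lies within the scatter), and ((methoxycarbonyl)methyl)amino on the aromatic carbon gives an at least 2.0-fold lower number from compound 1 to compound 3 (0.30 log units; that floor lies within the scatter); neither floor shows a step beyond the scatter, and neither fixes the true size. Compound 1 and compound 2 remain limits: the limit of > 20000 nM in this assay, at which 2 of the 3 values shown sit.

Open, going by these compounds, is whether the number goes with the ester or with the loss of the aromatic ring from the nitrogen substituent. A carboxylic acid or a benzyl group on this nitrogen would separate the two.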